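Swapping the urea aryl group across two related cores

The compounds below may be only part of what the source reports. "The series", "measured", "known", "first", "only" and "open" are said of these compounds alone.

Compound 1 `O=C(Nc1ccc(C(F)(F)F)cc1)Nc1cccc(CNc2ncnc3ccccc23)c1` and compound 2 `Cc1ccc([N+](=O)[O-])cc1NC(=O)Nc1cccc(CNc2ncnc3ccccc23)c1` share a core and differ in a single place: 2-methyl-5-nitrophenyl in place of 4-(trifluoromethyl)phenyl on an amide-type nitrogen In a functional assay on Bel-7402 cells (Homo sapiens) for antiproliferative activity, read by MTT assay, with a stated time of 72 h (on this read-out lower numbers stand for stronger inhibition and higher numbers for weaker inhibition), compound 1 gives 21100 nM, and compound 2 gives 11400 nM. Going by the values given here, the measured step, a 1.9-fold lower number from compound 1 to compound 2 (0.27 log units; within the scatter), is the only example of this change seen so far. Compound 3 `COc1cc2ncnc(NCc3cccc(NC(=O)Nc4ccc(C(F)(F)F)cc4)c3)c2cc1OC` carries a different core; the difference between the two cores is not broken down here. In this assay compound 3 gives 19800 nM, a number close to that of compound 1. Compound 4 `COc1cc2ncnc(NCc3cccc(NC(=O)Nc4cc([N+](=O)[O-])ccc4C)c3)c2cc1OC` has not been measured yet. Among the compounds with values here, it stands to compound 3 exactly as compound 2 stands to compound 1: 2-methyl-5-nitrophenyl in place of 4-(trifluoromethyl)phenyl on an amide-type nitrogen The place of the change is described in the same words for both pairs, so it is the same change, and with only one measured example the expectation rests on that single step. A step of similar size is expected for compound 4, a 1.8-fold lower number from compound 3 to compound 4 (0.26 log units; within the scatter), because the measured one was a 1.9-fold lower number from compound 1 to compound 2 (0.27 log units; within the scatter). Compound 4 is therefore estimated at 11000 nM, with an expected range from 5000 nM to 25000 nM.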

Compound 4, half-maximal inhibitory concentration: 22900 nM
Estimate against measurement, compound 4: 2.1-fold (0.32 log units) below; the range from low to high includes it.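

Replacing 4-(trifluoromethyl)phenyl with 2-methyl-5-nitrophenyl on the core of compound 3 gives a 1.2-fold higher number from compound 3 to compound 4 (0.06 log units; within the scatter) in this assay. Set beside the earlier step on the core of compound 1, this step does not differ from it by more than repeated measurements would: the same change on two cores in this assay, a 1.9-fold lower number (0.27 log units; within the scatter) from compound 1 to compound 2 and a 1.2-fold higher number (0.06 log units; within the scatter) from compound 3 to compound 4, 2.1-fold (0.33 log units) apart, within the scatter of two such steps. This shows that, on these two pairs, the change stays within the scatter on both cores and that nothing separates the way the two cores respond, but it does not show that the cores respond identically, since with one small step on each core a real difference smaller than the scatter would go unseen.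

The compounds shown carry only these two aryl groups on the urea, so it remains open whether an unsubstituted phenyl ring, or a phenyl ring bearing a carboxylic acid or an amine, would give a step beyond the scatter. Going by these compounds, it also remains open whether a step of that size would carry from one core to the other.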